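Removing one methoxy from compound 2: an expectation

This account rests on a few compounds, and the source may have more. Where it says the series, first, only, none or still open, it means among the compounds named here.

Measured so far:
compound 1, `COc1ccc(-c2cc(/C=C/C(=O)c3ccc(N)cc3)[nH]n2)cc1`, 91%
compound 2, `COc1cc(-c2cc(/C=C/C(=O)c3ccc(N)cc3)[nH]n2)cc(OC)c1OC`, 108%

Of the compounds shown here, two have been tested in a functional assay on IGROV-1 cells (Homo sapiens) for cytotoxicity, read by sulforhodamine B assay, with a stated time of 48 h, tested at 0.1 uM; on this read-out lower numbers stand for a stronger effect and higher numbers for a weaker effect at the one concentration tested. Compound 1 gives 91%, and compound 2 gives 108%. Among the compounds with values here, of these two numbers, compound 2 stands highest; the one other number, that of compound 1, is lower by a gap that goes beyond the usual scatter, so compound 2 shows the weaker effect of the two in this assay.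

The next compound, compound 3, `COc1ccc(-c2cc(/C=C/C(=O)c3ccc(N)cc3)[nH]n2)cc1OC`, has not been measured. It differs from compound 2 in one place: hydrogen in place of methoxy on an aromatic carbon. No change of this kind has been measured between two compounds here, so the size of the step can only be guessed from what compound 1 and compound 2 show. Compound 3 stands between them in the number of methoxy groups. The step from compound 2 to compound 3 is expected to be small, if anything toward a lower number, and most likely within the scatter: a number 8 percentage points lower from compound 2 to compound 3 (within the scatter). For compound 3 the expected value in this assay is 100%, within a range from 82% to 115%.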

Compound 3, a percentage reported as activity, at one concentration (the size of the read-out at that concentration, not a potency): 106%
Compound 3: the middle estimate sits 6 percentage points below what was measured; low and high end bracket the measured number.
By their numbers in this assay, from the lowest: compound 1; then compounds 3 and 2 (each within the scatter of the next).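

In this assay, hydrogen in place of methoxy on this aromatic carbon, ortho to a methoxy group and meta to a large group, gives a number 2 percentage points lower from compound 2 to compound 3 (within the scatter), so the methoxy at this position can be lost with no change that stands out from the scatter. The other single change tells a different story: methoxy in place of hydrogen on an aromatic carbon gives a number 15 percentage points higher from compound 1 to compound 3 (beyond the scatter), a modest step toward a weaker effect in this assay. Within the data shown here, of the two single changes now readable, only the one linking compound 1 and compound 3 moves the number beyond the scatter, so the gap between compound 1 and compound 2 is not matched by the step at this position. Nothing available here bears on why the two steps differ in size.

From the compounds shown here alone, what a hydroxyl, a fluorine or an ethoxy would do on this same aromatic carbon stays open. So does whether the two steps keep their sizes at a concentration other than the single one tested.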